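Swapping 2-bromophenyl for 4-methoxyphenyl in compound 3

This account rests on a few compounds, and the source may have more. Where it says the series, first, only, none or still open, it means among the compounds named here.

Measured in a functional assay on MCF7 cells (Homo sapiens) for cytotoxicity, read by MTT assay, with a stated time of 96 h; on this read-out higher numbers stand for weaker inhibition and lower numbers for stronger inhibition:
Compound 1 `COc1ccccc1-n1cc(C(=O)c2cc(OC)c(OC)c(OC)c2)c(-c2ccccc2)c1`: 150 nM
Compound 2 `COc1cc(C(=O)c2cn(-c3ccc(Br)cc3)cc2-c2ccccc2)cc(OC)c1OC`: 20 nM
Compound 3 `COc1cc(C(=O)c2cn(-c3ccccc3)cc2-c2ccccc2Br)cc(OC)c1OC`: 190 nM

Compound 3 lies within the scatter of compound 1, and its number is clearly higher than that of compound 2. Compound 4 `COc1ccc(-c2cn(-c3ccccc3)cc2C(=O)c2cc(OC)c(OC)c(OC)c2)cc1` carries 4-methoxyphenyl in place of 2-bromophenyl on an aromatic carbon. Within the data shown here, no measured step covers this carbon. The nearest evidence is a 7.5-fold lower number from compound 1 to compound 2 (0.88 log units; beyond the scatter), which concerns 4-bromophenyl in place of 2-methoxyphenyl on an aromatic nitrogen, so it bears only indirectly. A modest move towards stronger inhibition in this assay is therefore expected, smaller than that step, and none beyond the scatter remains possible. The expected change is a 2.4-fold lower number from compound 3 to compound 4 (0.38 log units; beyond the scatter). Compound 4 is estimated at 80 nM, with an expected range of 20 nM to 300 nM.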

Compound 4, half-maximal inhibitory concentration: 70 nM
The estimate for compound 4 lay 1.1-fold (0.06 log units) above the measured number, within the range that was stated.
By their numbers in this assay, from the lowest: compound 2; then compound 4; then compounds 1 and 3 (each within the scatter of the next).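

Among these compounds, the aryl group on this aromatic carbon, two ring bonds from the ring nitrogen, affects the number in this assay, with a 2.7-fold lower number from compound 3 to compound 4 (0.43 log units; beyond the scatter) giving the first measured step at this carbon. The swap of 2-bromophenyl for 4-methoxyphenyl changes both the substituent and where it sits on the phenyl ring, and this single step cannot separate the two changes. No evidence at hand accounts for the difference. Still open, as far as these compounds go, is how 4-aminophenyl, or a phenyl ring bearing a carboxylic acid, would read at this carbon.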